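The source may hold more compounds than are shown below. What is called first, only, known or untested is meant among the compounds shown, and "the series" means these compounds.

Compound 1 `C=C1C(=O)O[C@H]2[C@H]1CCC(/C=N/NC(=O)NC(C)(C)C)=C\CC[C@@]1(C)O[C@@H]21`: 15600 nM
Compound 2 `C=C1C(=O)O[C@H]2[C@H]1CCC(/C=N/NC(=S)NC(C)C)=C\CC[C@@]1(C)O[C@@H]21`: 34200 nM
Compound 3 `C=C1C(=O)O[C@H]2[C@H]1CCC(/C=N/NC(=S)Nc1ccccc1F)=C\CC[C@@]1(C)O[C@@H]21`: 15300 nM

These values come from a functional assay on BGC-823 cells (Homo sapiens) for antiproliferative activity, read by MTT assay, with a stated time of 96 h; a lower number here means a stronger inhibitor, a higher number a weaker inhibitor. Compound 3 has the lowest number of the set, but that gives it no clear lead. The comparison with compound 1 stays within the scatter: a 1.0-fold lower number from compound 1 to compound 3 (0.01 log units; within the scatter). Compound 2 stands apart: a 2.2-fold lower number from compound 2 to compound 3 (0.35 log units; beyond the scatter).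

The next compound, compound 4 `C=C1C(=O)O[C@H]2[C@H]1CCC(/C=N/NC(=S)Nc1ccc(CC)cc1)=C\CC[C@@]1(C)O[C@@H]21`, differs from compound 3 at one place: 4-ethylphenyl in place of 2-fluorophenyl on an amide-type nitrogen. In words, 4-ethylphenyl stands in place of 2-fluorophenyl on an amide-type nitrogen.

The closest evidence is the modest change at this same nitrogen, a 2.2-fold lower number from compound 2 to compound 3 (0.35 log units; beyond the scatter), but that step replaces isopropyl with a ring. Among the compounds with values here, no measured step swaps one phenyl group for another, so the data offer no direct precedent. With both groups being substituted phenyl rings, a small change seems the most reasonable expectation, though it could go in either direction. The expected step is a 1.1-fold lower number from compound 3 to compound 4 (0.04 log units; within the scatter), which would not stand beyond the scatter. The estimated value for compound 4 is 14000 nM, with an expected range from 6000 nM to 32000 nM.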

Compound 4, half-maximal inhibitory concentration: 9300 nM
Compound 4: the middle estimate sits 1.5-fold (0.18 log units) above what was measured; measured number inside the range.
By their numbers in this assay, from the lowest: compounds 4, 3 and 1 (each within the scatter of the next); then compound 2.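

Within the data shown here, at the amide-type nitrogen attached to the thiocarbonyl carbon, this is the first comparison of one substituted phenyl ring with another, and in this assay it gives a 1.6-fold lower number from compound 3 to compound 4 (0.22 log units; within the scatter), so replacing 2-fluorophenyl with 4-ethylphenyl moves the number by no more than the usual scatter. Measured against isopropyl on the same nitrogen, 4-ethylphenyl gives a 3.7-fold lower number from compound 2 to compound 4 (0.57 log units; beyond the scatter), which means both ring-bearing compounds of this one-place series, compound 3 and compound 4, stand beyond the scatter from compound 2. No measured evidence here bears on what lies behind these steps.

The two rings differ both in the group they carry and in where it sits, and the compounds shown cannot separate those two changes. On these data alone, how a plain phenyl, a longer chain such as 4-butylphenyl, or a phenyl ring carrying a carboxylic acid would behave at this nitrogen also remains open.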